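Fluoro for Methoxy on the Outer Phenyl Ring

A few compounds are considered here, and "the series" means these few. Any claim that something is new, unique, unknown or untested is made for them only; others in the source may bear on it.

Of the compounds shown here, three sharing one core have been tested in a functional assay on OVCAR-3 cells (Homo sapiens) for inhibition, read by sulforhodamine B assay, with a stated time of 48 h, tested at 10 uM; a higher number here means more inhibition at the concentration tested (going by the name of the read-out), a lower number less inhibition. Compound 1 `COc1ccc(-c2cn3ccnc3c(-c3ccc4ncn(C5CCCCC5)c4c3)n2)cc1` gives -26.5%. In this assay compound 2 `Fc1ccc(-c2cn3ccnc3c(-c3ccc4ncn(C5CCCCC5)c4c3)n2)cc1` gives 7.88%, and compound 3 `COc1ccccc1-c1cn2ccnc2c(-c2ccc3ncn(C4CCCCC4)c3c2)n1` gives 6.57%. Compound 2 differs from compound 1 by fluoro in place of methoxy on an aromatic carbon, and this change made a step of a number 34.4 percentage points higher from compound 1 to compound 2 (beyond the scatter). Compound 3 differs from compound 1 by 2-methoxyphenyl in place of 4-methoxyphenyl on an aromatic carbon, a step of a number 33.1 percentage points higher from compound 1 to compound 3 (beyond the scatter). Compound 2 and compound 3 lie within the scatter of each other, the step being a number 1.3 percentage points lower from compound 2 to compound 3 (within the scatter).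

Compound 4 `Fc1ccccc1-c1cn2ccnc2c(-c2ccc3ncn(C4CCCCC4)c3c2)n1` has not yet been measured. It differs from compound 3 by fluoro in place of methoxy on an aromatic carbon. Within the data shown here, this is the same kind of change as the one from compound 1 to compound 2, but the place differs: in the earlier pair the fluoro sits para to a large group, in the new pair ortho to a large group. The earlier step of a number 34.4 percentage points higher from compound 1 to compound 2 (beyond the scatter) started from compound 1 at -26.5%, well below where compound 3 stands at 6.57%. A smaller step is therefore expected in this assay, namely a number 3.4 percentage points higher from compound 3 to compound 4 (within the scatter). Compound 4 is estimated at 10%, expected to fall between -10% and 30%.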

Compound 4, a percentage reported as inhibition, at one concentration (the size of the read-out at that concentration, not a potency): 0.17%
For compound 4 the middle estimate is 9.8 percentage points above the measured one; the range from low to high includes it.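

In this assay the swap of fluoro for methoxy did not carry over from one core to the other: the same change on two cores in this assay, a number 34.4 percentage points higher (beyond the scatter) from compound 1 to compound 2 and a number 6.4 percentage points lower (within the scatter) from compound 3 to compound 4, 40.8 percentage points apart, beyond the scatter of two such steps

Among these compounds, the new pair shows no change beyond the scatter, with a number a number 6.4 percentage points lower from compound 3 to compound 4 (within the scatter), and moving the fluoro gives a similar picture, with a number 7.7 percentage points lower from compound 2 to compound 4 (within the scatter), so compound 2, compound 3 and compound 4 cannot be told apart here, while the only clear separation involves compound 1, with a number 26.7 percentage points higher from compound 1 to compound 4 (beyond the scatter). With a single pair on each core, this shows that the large earlier step cannot be assumed to hold elsewhere in the series, but it does not show why the two steps differ or what the swap would do on any third core.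

The compounds shown carry only fluoro or methoxy on the outer phenyl ring, so it remains open how an amine or a carboxylic acid would behave there. Also open, going by these compounds, is whether any such group would lift the reading clear of compound 2, compound 3 and compound 4.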